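This account rests on a few compounds, and the source may have more. Where it says the series, first, only, none or still open, it means among the compounds named here.

Measured compounds:
compound 1 `CNC(=O)NC[C@H]1O[C@@H](n2cnc3c(NC(=O)Nc4ccccc4)ncnc32)[C@H](OC(=O)c2ccccc2)[C@@H]1OC(=O)c1ccccc1` — in a functional assay on L1210 cells (Mus musculus) for antiproliferative activity, with a stated time of 48 h (a higher number here means a weaker inhibitor, a lower number a stronger inhibitor), compound 1 gives 154 ug/mL
compound 2 `CNC(=O)NC[C@H]1O[C@@H](n2cnc3c(N)ncnc32)[C@H](OC(C)=O)[C@@H]1OC(C)=O` — in this assay compound 2 gives 112 ug/mL

Compound 1 has the higher of the two numbers in this assay, but its nearest neighbour, compound 2, stands within the usual scatter of it, so the two compounds cannot be told apart on these data. Both are weak inhibitors by the half-maximal inhibitory concentration.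

The step of interest leads from compound 1 to compound 3 `CNC(=O)NC[C@H]1O[C@@H](n2cnc3c(N)ncnc32)[C@H](OC(=O)c2ccccc2)[C@@H]1OC(=O)c1ccccc1`, which has not yet been measured. The change is hydrogen in place of phenylcarbamoyl on a nitrogen on an aromatic ring. Compound 3 thus carries the free amino group of compound 2 on the shared core, while keeping the two benzoyl esters of compound 1.

For the measured compounds named here, no step between two measured compounds isolates this change. Going by the values given here, the only guide is that compound 2, which also bears the free amino group, lies within the scatter of compound 1. On that basis a step beyond the scatter is not expected; the estimated step of a 1.2-fold lower number from compound 1 to compound 3 (0.07 log units; within the scatter) is small. For compound 3 the value in this assay is estimated at 130 ug/mL, with a range from 60 ug/mL to 280 ug/mL.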

Compound 3, half-maximal inhibitory concentration: 16 ug/mL
For compound 3 the middle estimate is 8.1-fold (0.91 log units) above the measured one; the whole stated range lies above it.
By their numbers in this assay, from the lowest: compound 3; then compounds 2 and 1 (each within the scatter of the next).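

The phenylcarbamoyl group on the nitrogen on an aromatic ring was, until now, never varied on its own, and with the two benzoyl esters held fixed its replacement by hydrogen gives a 9.6-fold lower number from compound 1 to compound 3 (0.98 log units; beyond the scatter) in this assay. This shows that the position is not indifferent to what it carries: on this pair, the free amino compound is clearly the stronger inhibitor, and the phenylcarbamoyl group is a liability rather than a neutral addition. The compounds shown include no separate measurement that bears on why this step occurs.

This single pair leaves open whether the step would be of similar size with the acetyl esters of compound 2, and whether an acetyl or methylcarbamoyl group on the same nitrogen would stand closer to compound 1 or to compound 3. It also leaves open how far the value of compound 3 depends on its two benzoyl esters, and whether free hydroxyl groups or longer-chain esters such as hexanoyl in their place would keep the inhibition seen here.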